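Replacing the Sulfonamide Linker with an Amide in Compound 4

This account rests on a few compounds, and the source may have more. Where it says the series, first, only, none or still open, it means among the compounds named here.

Measured compounds:
compound 1 `CN(C)C(=O)c1cc2cnc(Nc3ccc(S(=O)(=O)NCCCCCN=C=S)cc3)nc2n1C1CCCC1` — 102%
compound 2 `CN(C)C(=O)c1cc2cnc(Nc3ccc(S(=O)(=O)NCCCCCCN=C=S)cc3)nc2n1C1CCCC1` — 101%
compound 3 `CN(C)C(=O)c1cc2cnc(Nc3ccc(S(=O)(=O)NCCCCCCCN=C=S)cc3)nc2n1C1CCCC1` — 101%

All three compounds were tested in a functional assay on A549 cells (Homo sapiens) for inhibition, read by CCK-8 assay, with a stated time of 72 h, tested at 10 uM; on this read-out higher numbers stand for a stronger effect at the one concentration tested and lower numbers for a weaker effect. Compound 1 holds the highest of the three numbers, but only nominally: a number 1 percentage points lower from compound 1 to compound 2 (within the scatter) and a number 1 percentage points lower from compound 1 to compound 3 (within the scatter) are both within the scatter, and no change at the digits printed from compound 2 to compound 3 (within the scatter) likewise, so the three compounds cannot be told apart on this read-out. Each of the measured steps lengthens the saturated chain between the sulfonamide nitrogen and the isothiocyanate by a single carbon, and none of them moved the number beyond the scatter.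

Compound 4 `CN(C)C(=O)c1cc2cnc(Nc3ccc(NC(=O)CCCCCCN=C=S)cc3)nc2n1C1CCCC1` is a different case. Relative to compound 1 the change is a group of 12 heavy atoms (8 carbon, 2 nitrogen, 1 oxygen, 1 sulfur; no ring) in place of a group of 12 heavy atoms (6 carbon, 2 nitrogen, 2 oxygen, 2 sulfur; no ring), on an aromatic carbon: the sulfonamide-bearing chain leaves and an amide-bearing chain enters, on an aromatic carbon of a six-membered aromatic ring of carbon only, para to a large group. For the measured compounds named here, no measured step touches this part of the molecule; the chain-length steps only show that the series is flat near the top of the scale. Because 102% for compound 1 is a strong inhibition on this read-out, compound 4 is expected to stay close, with a number 6 percentage points lower from compound 1 to compound 4 (within the scatter) reflecting mainly the uncertainty of an untested linker. The estimate for compound 4 is 96%, in the range 80% to 104%.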

Compound 4, a percentage reported as inhibition, at one concentration (the size of the read-out at that concentration, not a potency): 102%
Compound 4: the middle estimate sits 6 percentage points below what was measured, and the stated range covers the measured number.
By their numbers in this assay, from the lowest: compounds 2, 3, 1 and 4 (each within the scatter of the next).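

For the compounds shown here, with no change at the digits printed from compound 1 to compound 4 (within the scatter), the change on this aromatic carbon, para to a large group, is the first one to replace the sulfonamide-bearing chain with an amide-bearing chain, and this assay does not distinguish the two. The flat picture that compound 1, compound 2 and compound 3 gave for chain length therefore extends to this exchange of linker, although these numbers lie near the top of the scale and come from a single concentration, so they say nothing about potency. Nothing in the data shown bears on why the exchange leaves the number in place.

Still open, from the compounds shown here alone, is whether the amide-bearing chain would behave the same way with a shorter or longer chain, or with an amine or a carboxylic acid at the chain end in place of the isothiocyanate. A urea or a reversed amide on the same aromatic carbon remains open too, as does any difference among these compounds at lower concentrations.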